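Exchanging the azetidine of compound 2 for an aminophenyl

A few compounds are considered here, and "the series" means these few. Any claim that something is new, unique, unknown or untested is made for them only; others in the source may bear on it.

Measured so far:
compound 1, `FC(F)(F)c1cccc(CNc2cc(C(F)(F)F)cc3[nH]ncc23)c1`: 74%
compound 2, `FC(F)(F)c1cc(NCC2CNC2)c2cn[nH]c2c1`: 49%

Two compounds have been run in an assay for inhibition of Tryptophan 2,3-dioxygenase (Homo sapiens), with stated times of 10 min and 60 min, tested at 100 uM; on this read-out lower numbers stand for a weaker effect and higher numbers for a stronger effect at the one concentration tested. Compound 1 gives 74% in this assay, while compound 2 gives 49% in this assay. Compound 2 therefore stands lowest of the two, and its gap to compound 1 lies beyond the usual scatter of repeated measurements. Both compounds share the same core and the same saturated chain carbon bound to a nitrogen on that core; they differ only in the group carried on that carbon.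

Compound 3, `Nc1cccc(CNc2cc(C(F)(F)F)cc3[nH]ncc23)c1`, has not yet been measured. Its change from compound 2 is this: 3-aminophenyl in place of azetidin-3-yl on a saturated chain carbon bound to a nitrogen on an aromatic ring. Since compound 1, which also carries an aromatic ring on that saturated chain carbon, reaches 74% in this assay, an increase is expected for compound 3, and the step of a number 16 percentage points higher from compound 2 to compound 3 (beyond the scatter) is estimated to exceed the scatter. On that basis compound 3 is expected to give about 65% in this assay, within a range from 45% to 82%.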

Compound 3, a percentage reported as inhibition, at one concentration (the size of the read-out at that concentration, not a potency): 89%
Beside the measured number, compound 3's estimate is 24 percentage points below it; measured number above the stated range.
By their numbers in this assay, from the lowest: compound 2; then compound 1; then compound 3.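

In this assay, 3-aminophenyl in place of azetidin-3-yl on a saturated chain carbon bound to a nitrogen on an aromatic ring gives a number 40 percentage points higher from compound 2 to compound 3 (beyond the scatter). This shows that the group on this carbon can strongly move the read-out when all else stays the same. Amino in place of trifluoromethyl on an aromatic carbon gives a number 15 percentage points higher from compound 1 to compound 3 (beyond the scatter), so among these compounds the read-out depends on the group carried by the aromatic ring as well as on the presence of that ring, and the data offer no explanation for either step.

From the compounds shown here alone, it remains open whether this rise is particular to amino, as a plain phenyl ring or a hydroxyl, methoxy or acetamide group on the same aromatic carbon would be needed to tell. Going by these compounds, it also remains open how the three compounds compare in potency, as these numbers each come from a single concentration and a full concentration series would be needed to settle that.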